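This account rests on a few compounds, and the source may have more. Where it says the series, first, only, none or still open, it means among the compounds named here.

In a functional assay on MCF7 cells (Homo sapiens) for antiproliferative activity, read by MTT assay, with a stated time of 24 h (on this read-out higher numbers stand for weaker inhibition and lower numbers for stronger inhibition), compound 1 (`Cc1ccc(-c2nn(-c3ccccc3)cc2-c2nc3ccccc3[nH]2)cc1`) reads 7260 nM and compound 2 (`FC(F)(F)c1ccc(-c2nn(-c3ccccc3)cc2-c2nc3ccccc3[nH]2)cc1`) reads 6330 nM so the two stand level within the scatter. Compound 3 (`COc1ccc(S(=O)(=O)n2c(-c3cn(-c4ccccc4)nc3-c3ccc(C(F)(F)F)cc3)nc3ccccc32)cc1`) carries (4-methoxyphenyl)sulfonyl in place of hydrogen on an aromatic nitrogen. For the measured compounds named here, the one measured step (a 1.1-fold lower number from compound 1 to compound 2 (0.06 log units; within the scatter)) puts trifluoromethyl in place of methyl on an aromatic carbon, so it offers no direct guide to a change on this nitrogen. With nothing measured at this place, only a tentative fall in this assay is expected. The expected change is a 2.5-fold lower number from compound 2 to compound 3 (0.40 log units; beyond the scatter) as a rough guess. The estimate for compound 3 is 2500 nM (range 500 nM to 9000 nM).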

Compound 3, half-maximal inhibitory concentration: 420 nM
Compound 3: the middle estimate sits 6.0-fold (0.77 log units) above what was measured; the whole stated range lies above it.
By their numbers in this assay, from the lowest: compound 3; then compounds 2 and 1 (each within the scatter of the next).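

Putting (4-methoxyphenyl)sulfonyl in place of hydrogen on the aromatic nitrogen gives a 15-fold lower number from compound 2 to compound 3 (1.18 log units; beyond the scatter) in this assay, whereas the earlier change on an aromatic carbon stayed within the scatter. This nitrogen is therefore a place where a change can shift the read-out strongly, and the hydrogen on it is not needed for activity in these cells. No measurement here explains the drop.

Still open, going by these compounds, is whether the sulfonyl link or the 4-methoxyphenyl ring accounts for the step, and whether a group such as acetyl or benzyl on this nitrogen would do the same.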